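The source may hold more compounds than are shown below. What is called first, only, known or untested is meant among the compounds shown, and "the series" means these compounds.

Measured so far in a functional assay on MDA-MB-231 cells (Homo sapiens) for antiproliferative activity, read by MTT assay, with a stated time of 48 h; a higher number here means a weaker inhibitor, a lower number a stronger inhibitor:
compound 1 `COC(=O)CN(C)c1nc(Nc2ccc(Cl)cc2)ncc1[N+](=O)[O-]` gives 21200 nM
compound 2 `CCOC(=O)CN(Cc1ccccc1)c1nc(Nc2ccc(Cl)cc2)ncc1[N+](=O)[O-]` gives 34400 nM
compound 3 `CCOC(=O)CNc1nc(Nc2ccc(Cl)cc2)ncc1[N+](=O)[O-]` gives 55500 nM

Compound 2 stands second highest of the three numbers; the step of a 1.6-fold higher number from compound 2 to compound 3 (0.21 log units; within the scatter) and the gap to compound 1 both lie within the scatter, so the three cannot be ordered.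

Compound 4 `CCOC(=O)CNc1ncc([N+](=O)[O-])c(N(CC(=O)OCC)Cc2ccccc2)n1` differs from compound 2 by (ethoxycarbonyl)methyl in place of 4-chlorophenyl on a nitrogen on an aromatic ring. Among the compounds with values here, the measured steps, a 2.6-fold higher number from compound 1 to compound 3 (0.42 log units; beyond the scatter) and a 1.6-fold higher number from compound 2 to compound 3 (0.21 log units; within the scatter), both alter the other nitrogen on the shared core; the 4-chlorophenyl is common to all three measured compounds, so no step bears on its removal. The expected step of a 1.3-fold higher number from compound 2 to compound 4 (0.12 log units; within the scatter) is therefore set near zero, with a wide range. Compound 4 is estimated at 45000 nM in this assay, between 12000 nM and 170000 nM.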

Compound 4, half-maximal inhibitory concentration: 92500 nM
For compound 4 the middle estimate is 2.1-fold (0.31 log units) below the measured one; low and high end bracket the measured number.
By their numbers in this assay, from the lowest: compounds 1, 2, 3 and 4 (each within the scatter of the next, the first and the last beyond it).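

In this assay, within the data shown here, the first change at this nitrogen, (ethoxycarbonyl)methyl in place of 4-chlorophenyl, gives a 2.7-fold higher number from compound 2 to compound 4 (0.43 log units; beyond the scatter), so the position responds to substitution, though modestly. The change removes the only aromatic ring at this place and adds an ester, so this single step cannot separate the loss of one from the gain of the other. Nothing available on the series accounts for the step.

On these data alone, whether the chlorine or the ring itself matters remains open, and a plain phenyl or a cyclohexyl on this nitrogen would address that.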